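Anilide series: trifluoromethoxy for trifluoromethyl on the N-aryl ring

The source may hold more compounds than are shown below. What is called first, only, known or untested is meant among the compounds shown, and "the series" means these compounds.

Measured so far:
- compound 1, `COc1cc2c(Oc3ccc(NC(=O)c4nn(-c5ccccc5C)c(=O)cc4C)cc3F)ccnc2cc1OCCCN1CCCC1`, 2960 nM
- compound 2, `COc1cc2c(Oc3ccc(NC(=O)c4nn(-c5ccccc5C(F)(F)F)c(=O)cc4C)cc3F)ccnc2cc1OCCCN1CCCC1`, 1010 nM

Both numbers come from a functional assay on U-87MG ATCC cells (Homo sapiens) for inhibition, read by MTT assay, with a stated time of 72 h; a lower number here means a stronger inhibitor, a higher number a weaker inhibitor. Among the measured compounds shown here, compound 2 holds the lowest number of the two; compound 1 is its only neighbour, and the step of a 2.9-fold lower number from compound 1 to compound 2 (0.47 log units; beyond the scatter) separates them, beyond the scatter.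

Compound 3, `COc1cc2c(Oc3ccc(NC(=O)c4nn(-c5ccccc5OC(F)(F)F)c(=O)cc4C)cc3F)ccnc2cc1OCCCN1CCCC1`, has not been measured. It differs from compound 2 in one place: trifluoromethoxy in place of trifluoromethyl on an aromatic carbon. On the aromatic carbon carrying the group, ortho to a large group, a trifluoromethoxy stands in place of the trifluoromethyl.

For the measured compounds named here, the only measured step, a 2.9-fold lower number from compound 1 to compound 2 (0.47 log units; beyond the scatter), concerns the same position, but it swaps methyl for trifluoromethyl, not trifluoromethyl for trifluoromethoxy. It shows that this position tolerates a change of group with a modest shift in this assay; it does not say in which direction a further change would go. Going by the values given here, no step in the data is the same as the one to compound 3.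

Compound 3 is therefore expected near compound 2, with the step of a 1.3-fold higher number from compound 2 to compound 3 (0.11 log units; within the scatter) estimated to stay within the scatter. The estimate for compound 3 in this assay is 1300 nM, in the range 450 nM to 3800 nM.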

Compound 3, half-maximal inhibitory concentration: 1280 nM
Compound 3: middle estimate off by 1.0-fold (0.01 log units), on the high side, within the range that was stated.
By their numbers in this assay, from the lowest: compounds 2 and 3 (each within the scatter of the next); then compound 1.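

In this assay the step of a 1.3-fold higher number from compound 2 to compound 3 (0.10 log units; within the scatter) leaves trifluoromethoxy and trifluoromethyl on this aromatic carbon, ortho to a large group, indistinguishable, even though the entering group brings one more heavy atom and one hydrogen-bond acceptor by count. The earlier pair showed only that this position responds to a swap of methyl for trifluoromethyl; the step of a 2.3-fold lower number from compound 1 to compound 3 (0.36 log units; beyond the scatter) adds a second fluorinated group that also stands apart from methyl in the same direction, so among these three compounds the methyl compound is the one that reads differently. Nothing given here bears on why the two fluorinated groups read alike or why methyl does not.

The compounds shown leave open how a primary amine, a carboxylic acid or a longer alkoxy chain on this same aromatic carbon would read in this assay, since all three groups compared so far are small, uncharged and ringless. As far as these compounds go, the shared core stays fixed across the set, so it also remains open whether the likeness of trifluoromethoxy and trifluoromethyl would hold with a different group elsewhere on the molecule.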